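Shortening the enoyl chain on a trimethoxyphenyl amide

A few compounds are considered here, and "the series" means these few. Any claim that something is new, unique, unknown or untested is made for them only; others in the source may bear on it.

Working notes on a small set tested in a functional assay on HCT-116 cells (Homo sapiens) for inhibition, read by MTT assay, with a stated time of 48 h; a lower number here means a stronger inhibitor, a higher number a weaker inhibitor. Compound 1 `CCC/C=C/C(=O)N(Cc1ccc(OC)c(O)c1)c1cc(OC)c(OC)c(OC)c1` gives 95 nM and stands as the lower of the two numbers measured. Among the compounds with values here, compound 2 `COc1cc(NCc2cccc(O)c2)cc(OC)c1OC`, a secondary amine lacking the enoyl amide, gives 67700 nM; no step is defined between these two, and the values alone show compound 2 far weaker, beyond the scatter. The next compound in this assay is compound 3 `CC/C=C/C(=O)N(Cc1ccc(OC)c(O)c1)c1cc(OC)c(OC)c(OC)c1`, which differs from compound 1 by hydrogen in place of methyl on a saturated chain carbon, two bonds along the chain from a double-bonded chain carbon. A terminal trimming of this kind, with no ring, donor or acceptor touched, is expected to move the number little, likely none beyond the scatter, with a slight lean toward a weaker inhibitor. The expected step from compound 1 to compound 3 is a 1.6-fold higher number from compound 1 to compound 3 (0.20 log units; within the scatter). Compound 3 is estimated at 150 nM, within 50 nM to 500 nM.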

Compound 3, half-maximal inhibitory concentration: 63 nM
The estimate for compound 3 lay 2.4-fold (0.38 log units) above the measured number, and the stated range covers the measured number.
By their numbers in this assay, from the lowest: compounds 3 and 1 (each within the scatter of the next); then compound 2.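

In this assay the change from pent-1-en-1-yl to but-1-en-1-yl gives a 1.5-fold lower number from compound 1 to compound 3 (0.18 log units; within the scatter) and lies within the scatter, so compounds 1 and 3 cannot be told apart. Within the data shown here, this is the first single-place comparison in the set, and it shows that hydrogen in place of methyl at this saturated chain carbon leaves the number in the same range, so this one carbon is not required to keep it there. No measured evidence bears on this result.

On these data alone, whether the number holds with a still shorter chain, a longer chain, or a terminal amine or carboxylic acid on the chain remains open. Compound 2 differs from compounds 1 and 3 in more than one place, so the contribution of the enoyl amide itself also stays unresolved.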